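Swapping Methyl for Dimethylamino: Expectations for Compound 4

The compounds below may be only part of what the source reports. "The series", "measured", "known", "first", "only" and "open" are said of these compounds alone.

Measured so far:
Compound 1 `Cc1ccc(-c2cc3ccccc3[nH]2)cc1` gives 9.33%
Compound 2 `N#Cc1ccc2[nH]c(-c3ccccc3)cc2c1` gives 82.3%
Compound 3 `COCn1c(-c2ccccc2)cc2ccccc21` gives 20.2%

Of the compounds shown here, three have been tested in an assay on isolated protein for inhibition of Aromatase (Homo sapiens), read by fluorescence, using NADPH, with a stated time of 30 min, tested at 50 uM; on this read-out lower numbers stand for less inhibition and higher numbers for more inhibition at the one concentration tested (going by the name of the read-out). Compound 1 stands lowest of the three, with 9.33%. Its nearest neighbour is compound 3 at 20.2%, a gap that lies beyond the usual scatter, and the furthest is compound 2 at 82.3%, far beyond it. No pair among these three differs in only one place, so none of them shows directly what a single change does.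

Compound 4 `CN(C)c1ccc(-c2cc3ccccc3[nH]2)cc1` has not yet been measured. It differs from compound 1 in one spot: dimethylamino in place of methyl on an aromatic carbon. The group that leaves and the group that enters sit on the same carbon of the same six-membered ring, and the rest of the shared core stays unchanged.

Going by the values given here, with no measured step of this kind to lean on, the expectation for compound 4 is cautious: a small rise over compound 1, or no change beyond the scatter, is estimated, giving a number 10.7 percentage points higher from compound 1 to compound 4 (beyond the scatter). Compound 4 is therefore estimated at 20%, with a range from 3% to 45%.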

Compound 4, a percentage reported as inhibition, at one concentration (the size of the read-out at that concentration, not a potency): 0%
Estimate against measurement, compound 4: 20 percentage points above; measured number below the stated range.
By their numbers in this assay, from the lowest: compounds 4 and 1 (each within the scatter of the next); then compound 3; then compound 2.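

In this assay, going by these compounds alone, the swap of methyl for dimethylamino on this aromatic carbon gives a number 9.3 percentage points lower from compound 1 to compound 4 (within the scatter), and this is the first comparison in the set that isolates a single change. At this spot, para to a group of 9 heavy atoms, going from 1 heavy atom to 3 and adding a hydrogen-bond acceptor therefore produces no difference that can be told apart from ordinary scatter, so compound 1 and compound 4 read alike at the one concentration tested. Nothing measured here explains why they read alike.

On these data alone, whether a carboxylic acid or a longer chain such as butyl on the same carbon would read differently remains open. This single step also leaves open whether the same swap would behave alike on any other core.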